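This account rests on a few compounds, and the source may have more. Where it says the series, first, only, none or still open, it means among the compounds named here.

Among the measured compounds shown here, compound 2 `CCCCNC(=O)c1c(N)sc(-c2ccc(Cl)cc2)c1-c1ccc(Cl)cc1` gives 8170 nM in a functional assay on A549 cells (Homo sapiens) for inhibition, read by sulforhodamine B assay, with a stated time of 72 h (a lower number here means a stronger inhibitor, a higher number a weaker inhibitor), the higher of the two numbers measured so far. Compound 1 `CC1CN(C(=O)c2c(N)sc(-c3ccc(Cl)cc3)c2-c2ccc(Cl)cc2)CCN1` gives 4930 nM in this assay. For the measured compounds named here, the one measured step, a 1.7-fold higher number from compound 1 to compound 2 (0.22 log units; within the scatter), swapped the group on the carbonyl carbon and stayed within the scatter. Compound 3 `Nc1sc(-c2ccc(Cl)cc2)c(-c2ccc(Cl)cc2)c1C(=O)NC1CC1` carries cyclopropyl in place of butyl on an amide-type nitrogen. Going by the values given here, no measured compound bears a cyclopropyl, so only that earlier amide step informs the expectation, and a similarly small shift seems likely. The estimated step is a 1.0-fold lower number from compound 2 to compound 3 (0.01 log units; within the scatter), with no clear direction. Compound 3 is estimated at 8000 nM, with a range from 3000 nM to 20000 nM.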

Compound 3, half-maximal inhibitory concentration: 1950 nM
Compound 3: the middle estimate sits 4.1-fold (0.61 log units) above what was measured; the measured number lies below the stated range.
By their numbers in this assay, from the lowest: compound 3; then compounds 1 and 2 (each within the scatter of the next).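

Cyclopropyl in place of butyl on the amide-type nitrogen gives a clear change, a 4.2-fold lower number from compound 2 to compound 3 (0.62 log units; beyond the scatter), whereas the earlier step on the carbonyl carbon stayed within the scatter. Cyclopropylamino in place of 3-methylpiperazin-1-yl gives a 2.5-fold lower number from compound 1 to compound 3 (0.40 log units; beyond the scatter), so compound 3 has the lowest number of the three, with its steps to both others beyond the scatter. Nothing available here explains this difference. Whether the ring or the smaller carbon count matters remains open: an isopropyl, a propyl chain or a cyclobutyl on this nitrogen would separate the two, and none stands among the compounds shown.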